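The source may report more compounds than this note shows. Statements on the series, on what has been measured and on what is new or still open speak of the compounds shown alone.

Values in a functional assay on KB cells (Homo sapiens) for cytotoxicity; on this read-out higher numbers stand for weaker inhibition and lower numbers for stronger inhibition:
Compound 1 `CC(C)(C)c1ccc([N+](C)(C)CCCNc2cc(Cl)ccc2Sc2ccccc2)cc1`: 2.14 ug/mL
Compound 2 `CCCC(=O)Nc1cc(Cl)ccc1Sc1ccccc1`: > 300 ug/mL, a limit of the assay and not a number
Compound 3 `O=[N+]([O-])c1cc(Cl)ccc1Sc1ccccc1`: 43.1 ug/mL

Of the two actual numbers, the higher belongs to compound 3 at 43.1 ug/mL, and compound 1 stands lower at 2.14 ug/mL.

The change to follow is amino in place of nitro on an aromatic carbon, ortho to a group of 7 heavy atoms and meta to a chloro group. It turns compound 3 into compound 4 `Nc1cc(Cl)ccc1Sc1ccccc1` (amino in place of nitro on an aromatic carbon).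

Among the compounds with values here, one measured step concerns the same carbon: an at least 6.9-fold lower number from compound 2 to compound 3 (0.84 log units; beyond the scatter). Its size is only a bound: the limit of > 300 ug/mL in this assay, at which 1 of the 3 values shown sits. Within the data shown here, it shows that the group on this carbon can move the value, but no measured step involves the amino group, so the direction stays open.

The expected result in this assay is no shift beyond the scatter, with a 1.4-fold lower number from compound 3 to compound 4 (0.16 log units; within the scatter) as the estimated step. The estimate for compound 4 is 30 ug/mL, with an expected range of 8 ug/mL to 120 ug/mL.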

Compound 4, half-maximal inhibitory concentration: 47.9 ug/mL
For compound 4 the middle estimate is 1.6-fold (0.20 log units) below the measured one, within the range that was stated.
By their numbers in this assay, from the lowest: compound 1; then compounds 3 and 4 (each within the scatter of the next). At a limit, above all of these: compound 2.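

In this assay, putting amino in place of nitro on this aromatic carbon gives a 1.1-fold higher number from compound 3 to compound 4 (0.05 log units; within the scatter), so the two groups cannot be told apart here despite their different hydrogen-bond donor and acceptor counts. Taking propylcarbonyl off the nitrogen gives an at least 6.2-fold lower number from compound 2 to compound 4 (0.79 log units; beyond the scatter), which places the loss of activity in compound 2 on the acylated nitrogen and not on the absence of nitro. That size is only a bound, since compound 2 stands at a limit and not a number: the limit of > 300 ug/mL in this assay, at which 1 of the 4 values shown sits.

Which acyl feature matters stays open, as the shorter acetyl or a longer chain on the same nitrogen could fall on either side. A carboxylic acid or a methylamino group on this carbon could likewise stay with compound 3 and compound 4 or move away from them.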